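Lactone series: bromophenyl to trifluoromethylbenzyloxy swap

The source may report more compounds than this note shows. Statements on the series, on what has been measured and on what is new or still open speak of the compounds shown alone.

Measured so far:
compound 1 `CCC1(c2ccccc2)CC(=O)C(C2CC(c3ccc(OC)cc3)Cc3ccccc32)=C(O)O1` — > 10000 nM
compound 2 `CCCC1(CCc2ccccc2)CC(=O)C(C2CC(c3ccc(-c4ccc(Br)cc4)cc3)Cc3ccccc32)=C(O)O1` — > 10000 nM

Two compounds of the shared core have been run in a functional assay on HCT-15 cells (Homo sapiens) for inhibition, with a stated time of 72 h; on this read-out higher numbers stand for weaker inhibition and lower numbers for stronger inhibition. Compound 1 gives only a limit, > 10000 nM. Compound 2 likewise gives only a limit, > 10000 nM. Within the data shown here, both values therefore stand at the limit of > 10000 nM in this assay, at which 2 of the 2 values shown sit, and no step between measured compounds can be drawn; where compound 2 stands relative to compound 1 cannot be told beyond the fact that both are limits.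

The next compound, compound 3 `CCCC1(CCc2ccccc2)CC(=O)C(C2CC(c3ccc(OCc4ccc(C(F)(F)F)cc4)cc3)Cc3ccccc32)=C(O)O1`, differs from compound 2 in one place: (4-(trifluoromethyl)benzyl)oxy in place of 4-bromophenyl on an aromatic carbon. The propyl and phenethyl substituents on the lactone carbon and the rest of the core are kept.

Among the measured compounds shown here, with no measured step to lean on and compound 2 sitting at the limit of > 10000 nM in this assay, at which 2 of the 2 values shown sit, the working expectation is that compound 3 stays at the limit as well. The estimated step that the limit leaves unreadable from compound 2 to compound 3 is none beyond the scatter, in either direction. Compound 3 is thus expected at 15000 nM, with a range from 4000 nM to 60000 nM, most probably reported again as a limit rather than a number.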

Compound 3, half-maximal inhibitory concentration: > 10000 nM
Compound 3 ended at the assay's limit; the forecaster's own chance of this, stated with the estimate: 80%; the middle value is on the limit's open side.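

Compound 3 sits at the same limit as compound 2, and no step between the two can be read: the limit of > 10000 nM in this assay, at which 3 of the 3 values shown sit.

Going by these compounds, whether any compound of the shared core gives a measurable value in this assay, and how the 4-bromophenyl and (4-(trifluoromethyl)benzyl)oxy groups compare there, remains open.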